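Aryl Sulfone Swap on a Quinoline Core

The source may hold more compounds than are shown below. What is called first, only, known or untested is meant among the compounds shown, and "the series" means these compounds.

Compound 1 `COc1ccc(S(=O)(=O)c2cnc3cc(F)ccc3c2N2CCC(C)CC2)cc1OC` is measured in an assay on isolated protein for displacement of a labelled ligand from metabotropic glutamate receptor 5 (Homo sapiens), with a stated time of 60 min, tested at 1 uM (on this read-out higher numbers stand for more inhibition at the one concentration tested (going by the name of the read-out) and lower numbers for less inhibition), where it gives 83%. Among the three measured analogues it holds the second highest number: compound 2 `Cc1ccc2ncc(S(=O)(=O)c3cc(Cl)cc(Cl)c3)c(N3CCC(C)CC3)c2c1` gives 75%, a value within the usual scatter of compound 1, while compound 3 `Cc1ccc(S(=O)(=O)c2cnc3cc(Cl)ccc3c2N2CCC(C)CC2)cc1` gives 94%, a number beyond the scatter above it. Going by the values given here, no step between measured compounds is recorded that isolates a single change. Compound 4 `CC1CCN(c2c(S(=O)(=O)c3ccc(F)c(F)c3)cnc3cc(F)ccc23)CC1` differs from compound 1 by 3,4-difluorophenyl in place of 3,4-dimethoxyphenyl on a sulfonyl sulfur. Since every aryl variant measured so far lands in a similar band, the step from compound 1 to compound 4 is expected to be small, with a number 3 percentage points lower from compound 1 to compound 4 (within the scatter) in this assay likely within the scatter. Compound 4 is estimated at 80%, with a range from 60% to 95%.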

Compound 4, a percentage reported as inhibition, at one concentration (the size of the read-out at that concentration, not a potency): 94%
Beside the measured number, compound 4's estimate is 14 percentage points below it, within the range that was stated.
By their numbers in this assay, from the lowest: compounds 2 and 1 (each within the scatter of the next); then compounds 3 and 4 (each within the scatter of the next).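

With 3,4-difluorophenyl in place of 3,4-dimethoxyphenyl on a sulfonyl sulfur, this assay shows a number 11 percentage points higher from compound 1 to compound 4 (beyond the scatter) as a modest step. Going by these compounds alone, this is the first single change, and it shows that the aryl group at this place can move the number beyond the scatter. No available evidence explains the step.

The compounds shown leave open whether the step comes from gaining the fluorines or from losing the methoxy groups. They also leave open how an aryl group carrying an amine or a carboxylic acid would read out at this place.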